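This account rests on a few compounds, and the source may have more. Where it says the series, first, only, none or still open, it means among the compounds named here.

Compound 1, with the structure `O=C1/C(=C/c2ccc(Br)cc2)Cc2ccccc21`, is tested in a functional assay on L1210 cells (Mus musculus) for inhibition (a lower number here means a stronger inhibitor, a higher number a weaker inhibitor), where compound 1 gives 64800 nM. Compound 2, with the structure `Cc1ccc(/C=C2\Cc3ccccc3C2=O)cc1`, differs from compound 1 in one place: methyl in place of bromo on an aromatic carbon. In this assay compound 2 gives 59100 nM, so that the step of a 1.1-fold lower number from compound 1 to compound 2 (0.04 log units; within the scatter) does not separate the two compounds from each other.

Compound 3, with the structure `O=C1/C(=C/c2cccc(Br)c2)CCCc2ccccc21`, has a different core from compound 1, and the difference between the two cores is not broken down here. In this assay compound 3 gives 51000 nM, a number that lies within the scatter of both compound 1 and compound 2.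

Compound 4, with the structure `Cc1cccc(/C=C2\CCCc3ccccc3C2=O)c1`, has not yet been measured in this assay. It differs from compound 3 in one place: methyl in place of bromo on an aromatic carbon. Within the data shown here, this is the same kind of change as the one from compound 1 to compound 2, though not the same, as the group in compound 2 sits para to a large group while in compound 4 it sits meta to a large group.

Since the step from compound 1 to compound 2 was a 1.1-fold lower number from compound 1 to compound 2 (0.04 log units; within the scatter), a step of similar size is expected for compound 4, namely a 1.1-fold lower number from compound 3 to compound 4 (0.04 log units; within the scatter). Compound 4 is therefore estimated to give about 47000 nM in this assay, with a likely range from 25000 nM to 90000 nM, because compound 3 gives 51000 nM and the earlier change moved the number only slightly.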

Compound 4, half-maximal inhibitory concentration: 54400 nM
The estimate for compound 4 lay 1.2-fold (0.06 log units) below the measured number; the measured number falls inside the stated range.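

In this assay, methyl in place of bromo gives a 1.1-fold higher number from compound 3 to compound 4 (0.03 log units; within the scatter), so this change does not separate the two compounds. Set beside the earlier step, the same change gives a matching result on the two cores, with no difference that can be told apart from ordinary variation between repeated measurements: the same change on two cores in this assay, a 1.1-fold lower number (0.04 log units; within the scatter) from compound 1 to compound 2 and a 1.1-fold higher number (0.03 log units; within the scatter) from compound 3 to compound 4, 1.2-fold (0.07 log units) apart, within the scatter of two such steps. This shows that, in these two pairs, swapping bromo for methyl leaves the number essentially where it was, but it does not show that the swap would be equally quiet on other cores, and the two pairs also differ in where the group sits on the aromatic ring, so the role of the core cannot be separated from the role of that position.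

The compounds shown leave open whether the number in this assay would respond to a group of a different kind on this aromatic ring, such as an amine, a carboxylic acid or a longer alkyl chain, since bromo and methyl are the only two compared here. They also leave open whether the same swap would stay this quiet on a compound with a much lower number in this assay.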